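Pyridyl-to-halophenyl swap on the oxadiazole arm

The source may hold more compounds than are shown below. What is called first, only, known or untested is meant among the compounds shown, and "the series" means these compounds.

Measured so far in a functional assay on HCT-116 cells (Homo sapiens) for positive allosteric modulation, read by MTT assay, with stated times of 24 h and 48 h, tested at 2.5 uM; on this read-out lower numbers stand for less inhibition of growth and higher numbers for more inhibition of growth at the one concentration tested:
compound 1, `CS(=O)(=O)c1ccc(-c2cnc3[nH]cc(-c4nnc(-c5ccncc5)o4)c(=O)c3c2)cc1`: 29.2%
compound 2, `CS(=O)(=O)c1ccc(-c2cnc3[nH]cc(-c4nnc(-c5ccc(F)cc5)o4)c(=O)c3c2)cc1`: 39.5%
compound 3, `CS(=O)(=O)c1ccc(-c2cnc3[nH]cc(-c4nnc(-c5ccccn5)o4)c(=O)c3c2)cc1`: 34.3%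

Compound 3 sits among the three numbers with a number 5.1 percentage points higher from compound 1 to compound 3 (within the scatter) and a number 5.2 percentage points lower from compound 2 to compound 3 (within the scatter), both within the scatter, so it is not separated from either neighbour. Compound 4, `CS(=O)(=O)c1ccc(-c2cnc3[nH]cc(-c4nnc(-c5ccc(Cl)cc5)o4)c(=O)c3c2)cc1`, differs from compound 3 by 4-chlorophenyl in place of pyridin-2-yl on an aromatic carbon. The step that bears on this is the earlier change from a pyridyl ring to a halogenated phenyl ring, a number 10.3 percentage points higher from compound 1 to compound 2 (beyond the scatter), a modest rise; the return from that phenyl to the pyridin-2-yl of compound 3 was a number 5.2 percentage points lower from compound 2 to compound 3 (within the scatter), within the scatter. For compound 4 a modest rise is therefore expected, a number 5.7 percentage points higher from compound 3 to compound 4 (within the scatter). The estimate for compound 4 is 40%, in the range 28% to 52%.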

Compound 4, percent growth inhibition at one concentration: 24.9%
Compound 4: the middle estimate sits 15.1 percentage points above what was measured; measured number outside the range, below it.
By their numbers in this assay, from the lowest: compounds 4, 1, 3 and 2 (each within the scatter of the next, the first and the last beyond it).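

For the compounds shown here, the halogen on this phenyl ring decides the reading in this assay: a number 14.6 percentage points lower from compound 2 to compound 4 (beyond the scatter), the one new step beyond the scatter, so the result for 4-fluorophenyl does not carry over to 4-chlorophenyl. Against the pyridyl compounds, 4-chlorophenyl is not separated, with a number 9.4 percentage points lower from compound 3 to compound 4 (within the scatter) and a number 4.3 percentage points lower from compound 1 to compound 4 (within the scatter), so a phenyl ring in place of a pyridyl ring does not raise the number by itself. Nothing available explains the gap between the two halogens. Open, going by these compounds, is how a 4-bromophenyl or 4-methoxyphenyl group would stand against this fluoro and chloro pair.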